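The compounds below may be only part of what the source reports. "The series", "measured", "known", "first", "only" and "open" are said of these compounds alone.

Measured so far:
- compound 1 `CCOc1ccc(CNC(=O)c2ccc(C(C)(C)C)cc2)cc1` gives 160 nM in an assay on HeLa cells with Bile acid receptor (Homo sapiens) as the target, read by a luciferase reporter, with a stated time of 24 h; a higher number here means that more compound is needed for the effect, a lower number that less compound is needed
- compound 2 `CSc1ccc(CNC(=O)c2ccc(C(C)(C)C)cc2)cc1` gives 100 nM in this assay
- compound 3 `CC(C)(C)c1ccc(C(=O)NCc2ccc(SC(F)(F)F)cc2)cc1` gives 0.4 nM in this assay

Compound 3 has the lowest number of the three: a 250-fold lower number from compound 2 to compound 3 (2.40 log units; beyond the scatter) and a 400-fold lower number from compound 1 to compound 3 (2.60 log units; beyond the scatter), both well beyond the scatter. Compound 4 `COc1ccc(CNC(=O)c2ccc(C(C)(C)C)cc2)cc1` differs from compound 3 by methoxy in place of (trifluoromethyl)sulfanyl on an aromatic carbon. Within the data shown here, the steps that bear on this are the two that reached compound 3, a 400-fold lower number from compound 1 to compound 3 (2.60 log units; beyond the scatter) and a 250-fold lower number from compound 2 to compound 3 (2.40 log units; beyond the scatter), while a 1.6-fold lower number from compound 1 to compound 2 (0.20 log units; within the scatter) shows that the two small groups sit close together. Removing the (trifluoromethyl)sulfanyl is therefore expected to undo most of that gain, a large upward step in this assay. Compound 4 is estimated at 180 nM, range 50 nM to 700 nM. This means an expected step of a 450-fold higher number from compound 3 to compound 4 (2.65 log units; beyond the scatter).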

Compound 4, half-maximal effective concentration: 150 nM
Beside the measured number, compound 4's estimate is 1.2-fold (0.08 log units) above it, within the range that was stated.
By their numbers in this assay, from the lowest: compound 3; then compounds 2, 4 and 1 (each within the scatter of the next).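

In this assay methoxy on this aromatic carbon, para to a large group, reads the same as methylsulfanyl (a 1.5-fold higher number from compound 2 to compound 4 (0.18 log units; within the scatter)) and ethoxy (a 1.1-fold lower number from compound 1 to compound 4 (0.03 log units; within the scatter)). The three small groups now form a flat set, so the oxygen-to-sulfur exchange and the extra methyl carry no readable change here. Only (trifluoromethyl)sulfanyl stands apart, and direct exchange for methoxy gives the full gap (a 380-fold higher number from compound 3 to compound 4 (2.57 log units; beyond the scatter)).

No measurement shown offers an explanation for this gap.

Open, from the compounds shown here alone, is whether trifluoromethoxy at this place would read with (trifluoromethyl)sulfanyl or with the small groups. Also open, going by these compounds, is how an amine or a longer alkoxy chain would read there.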